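Aryl variation on the semicarbazone of a shared core

The source may hold more compounds than are shown below. What is called first, only, known or untested is meant among the compounds shown, and "the series" means these compounds.

Three measured compounds share one core and differ only in the aryl group on the carbon with a double bond to nitrogen. In a functional assay on HT-29 cells (Homo sapiens) for cytotoxicity, read by MTT assay, with a stated time of 72 h (on this read-out lower numbers stand for stronger inhibition and higher numbers for weaker inhibition), compound 1 `CN(C)CCn1cnnc1-c1cc(Oc2ccc(NC(=O)N/N=C/c3ccc(Cl)cc3Cl)cc2F)ccn1` gives 390 nM, compound 2 `CN(C)CCn1cnnc1-c1cc(Oc2ccc(NC(=O)N/N=C/c3ccc(O)c(Br)c3)cc2F)ccn1` gives 450 nM, and compound 3 `COc1cc(/C=N/NC(=O)Nc2ccc(Oc3ccnc(-c4nncn4CCN(C)C)c3)c(F)c2)cc(OC)c1OC` gives 3620 nM. Compound 2 stands second highest of the three numbers: the step of a 1.2-fold higher number from compound 1 to compound 2 (0.06 log units; within the scatter) lies within the scatter, while an 8.0-fold higher number from compound 2 to compound 3 (0.91 log units; beyond the scatter) and a 9.3-fold higher number from compound 1 to compound 3 (0.97 log units; beyond the scatter) are modest rises beyond it.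

Compound 4 `CN(C)CCn1cnnc1-c1cc(Oc2ccc(NC(=O)N/N=C/c3ccc(O)cc3)cc2F)ccn1` differs from compound 2 by hydrogen in place of bromo on an aromatic carbon. Among the measured compounds shown here, no measured step removes a single substituent on this ring; all measured steps exchange the whole aryl group. The closest guide is that compound 1 and compound 2 carry different halogen patterns yet sit within the scatter of each other, whereas only the trimethoxy change of compound 3 moves the number. The step of a 1.4-fold higher number from compound 2 to compound 4 (0.16 log units; within the scatter) is therefore expected to be small, at most a slight rise. Compound 4 is estimated at 650 nM in this assay, with a range from 300 nM to 1500 nM.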

Compound 4, half-maximal inhibitory concentration: 1920 nM
The estimate for compound 4 lay 3.0-fold (0.47 log units) below the measured number; the measured number lies above the stated range.
By their numbers in this assay, from the lowest: compounds 1 and 2 (each within the scatter of the next); then compounds 4 and 3 (each within the scatter of the next).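

In this assay, the bromo of the 3-bromo-4-hydroxyphenyl group matters: a 4.3-fold higher number from compound 2 to compound 4 (0.63 log units; beyond the scatter), so a single atom ortho to a hydroxy group moves the number beyond the scatter, which the earlier exchanges of whole aryl groups could not isolate. The 4-hydroxyphenyl group also separates from 2,4-dichlorophenyl, with a 4.9-fold higher number from compound 1 to compound 4 (0.69 log units; beyond the scatter), yet stays level with 3,4,5-trimethoxyphenyl, with a 1.9-fold lower number from compound 3 to compound 4 (0.28 log units; within the scatter), so among these four compounds the two halogen-bearing aryl groups, in compound 1 and compound 2, give the lower numbers, and no compound goes against this. No measurement at hand explains the step.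

From the compounds shown here alone, it remains open whether the gain belongs to bromo itself or to any group on that carbon, such as chloro, methyl or an amine. Among the compounds shown here, the separate contribution of the hydroxy group also remains open, as no pair here isolates it.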